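From 3-Bromophenyl to 4-Bromobenzyl: An Expected Value

The compounds below may be only part of what the source reports. "The series", "measured", "known", "first", "only" and "open" are said of these compounds alone.

Of the compounds shown here, two sharing one core have been measured in an assay on CHO cells for displacement of a labelled ligand from adenosine receptor A1 (Homo sapiens), read by scintillation counting, with a stated time of 90 min, in the presence of a further agent that is not named here; a lower number here means a stronger inhibitor, a higher number a weaker inhibitor. Compound 1 `CCCn1c(=O)c2[nH]c(-c3ccc(S(=O)(=O)N4CCN(c5ccc(Cl)cc5)CC4)cc3)nc2n(CC)c1=O` carries a 4-chlorophenyl on the ring amine of its sulfonamide-linked ring; in this assay compound 1 gives > 1000 nM, which is a limit of the assay rather than a number. Compound 2 `CCCn1c(=O)[nH]c2nc(-c3ccc(S(=O)(=O)N4CCN(c5cccc(Br)c5)CC4)cc3)[nH]c2c1=O` differs in its core and carries a 3-bromophenyl; in this assay compound 2 gives > 1000 nM, again a limit and not a number. Compound 2 therefore stands at the edge of what this assay reports, as noted in the limit of > 1000 nM in this assay, at which 2 of the 2 values shown sit.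

Compound 3 `CCCn1c(=O)[nH]c2nc(-c3ccc(S(=O)(=O)N4CCN(Cc5ccc(Br)cc5)CC4)cc3)[nH]c2c1=O` is the next compound, not yet measured in this assay. Its structure differs from compound 2 in one place: 4-bromobenzyl in place of 3-bromophenyl on an amine nitrogen in a ring.

Within the data shown here, no step between measured compounds is recorded, so the size of this change is not known from the data. Compound 3 is expected to remain near the limit, with an estimate of 3000 nM, ranging from 500 nM to 20000 nM. The expected step that the limit leaves unreadable from compound 2 to compound 3 is therefore small and not beyond the scatter.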

Compound 3, inhibition constant: > 1000 nM
Compound 3: only a limit was reported; the forecaster's own chance of this, stated with the estimate: 75%; the middle value does not contradict the limit.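

In this assay compound 3 gives > 1000 nM, which is a limit of the assay and not a number. Among these compounds, compound 2 also stands at a limit, so no step from compound 2 to compound 3 can be read: the limit of > 1000 nM in this assay, at which 3 of the 3 values shown sit. The compounds shown leave open whether 4-bromobenzyl or 3-bromophenyl gives the stronger inhibitor in this assay.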